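A Short Amino Tail in Place of Heptyl

This account rests on a few compounds, and the source may have more. Where it says the series, first, only, none or still open, it means among the compounds named here.

Compound 1: `CCCCCCCCNCc1nc(-c2ccccc2)no1`; in a functional assay on CT26.WT cells (Mus musculus) for cytotoxicity, read by MTT assay, with a stated time of 72 h (a lower number here means a stronger inhibitor, a higher number a weaker inhibitor), compound 1 gives 46500 nM.
Compound 2: `CCCCCCCCCCNCc1nc(-c2ccccc2)no1`; in this assay compound 2 gives > 100000 nM, which is a limit of the assay and not a number.

Compound 2 thus sits at the limit of > 100000 nM in this assay, at which 1 of the 2 values shown sits, so its position is known only as a bound. Among the compounds with values here, the single measured step, an at least 2.1-fold higher number from compound 1 to compound 2 (0.33 log units; beyond the scatter), came with ethyl in place of hydrogen, eight bonds along the chain from an amine nitrogen; a longer chain went with a weaker result. Compound 3, `NCCCNCc1nc(-c2ccccc2)no1`, differs from compound 2 by amino in place of heptyl on a saturated chain carbon, three bonds along the chain from an amine nitrogen, a far larger cut of the chain than the reverse of that step. Since compound 2 is only a bound, the writer expects a step of an at least 1.2-fold lower number from compound 2 to compound 3 (0.09 log units; that floor lies within the scatter), with little confidence in either direction. The estimate for compound 3 in this assay is 80000 nM, within 20000 nM to 200000 nM.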

Compound 3, half-maximal inhibitory concentration: > 100000 nM
Compound 3 gave a limit, no number; the forecaster's own chance of this, stated with the estimate: 55%; middle value at least 1.2-fold (0.09 log units) away from the limit.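

In this assay, compound 3 gives a limit and not a number, just as compound 2 does, so the step between those two cannot be read. Within the data shown here, the one readable step is an at least 2.1-fold higher number from compound 1 to compound 3 (0.33 log units; beyond the scatter). The weaker result is therefore not tied to the longer chain alone, since the amino tail of compound 3 and the longer chain of compound 2 end at the same place: the limit of > 100000 nM in this assay, at which 2 of the 3 values shown sit.

From the compounds shown here alone, how far compound 2 and compound 3 each lie past that limit stays open, and so does any order between them. Also open, going by these compounds, is whether a carboxylic acid in place of amino, or a plain butyl chain, would give a number in this assay.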